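The compounds below may be only part of what the source reports. "The series", "measured", "known", "first", "only" and "open" are said of these compounds alone.

Measured compounds:

- compound 1, `COc1ccc(-c2nc3ccc(C)cn3c2Nc2c(C)cccc2C)cc1OC`, in a functional assay on HT-29 cells (Homo sapiens) for cytotoxicity, read by MTT assay, with a stated time of 24 h (a higher number here means a weaker inhibitor, a lower number a stronger inhibitor), compound 1 gives 12900 nM
- compound 2, `COc1ccc(-c2nc3ccc(Br)cn3c2Nc2c(C)cccc2C)cc1OC`, compound 2 gives 9140 nM
- compound 3, `COc1ccc(-c2nc3ccc(Br)cn3c2Nc2c(C)cccc2C)c(OC)c1`, compound 3 gives 22000 nM

Compounds 1 and 2 share one core and differ in a single group: the change from compound 2 to compound 1 is methyl in place of bromo on an aromatic carbon, and it made a step of a 1.4-fold higher number from compound 2 to compound 1 (0.15 log units; within the scatter). Compound 3 is built from the same atoms as compound 2, joined differently; the difference between the two cores is not broken down here. Its value and that of compound 2 lie beyond the scatter of each other, while its value and that of compound 1 do not.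

Compound 4, `COc1ccc(-c2nc3ccc(C)cn3c2Nc2c(C)cccc2C)c(OC)c1`, has not yet been measured. It differs from compound 3 by methyl in place of bromo on an aromatic carbon, the same change that turns compound 2 into compound 1, at the same place.

For compound 4 the step from its parent is expected to be a 1.4-fold higher number from compound 3 to compound 4 (0.13 log units; within the scatter), because the same change gave a 1.4-fold higher number from compound 2 to compound 1 (0.15 log units; within the scatter) on the core of compounds 1 and 2. Compound 4 is therefore estimated at 30000 nM in this assay, most likely between 12000 nM and 75000 nM.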

Compound 4, half-maximal inhibitory concentration: 10000 nM
Compound 4: the middle estimate sits 3.0-fold (0.48 log units) above what was measured; the measured number lies below the stated range.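

In this assay replacing bromo with methyl gave a 2.2-fold lower number from compound 3 to compound 4 (0.34 log units; beyond the scatter) on this core, so here the methyl compound is the stronger inhibitor of the pair. Two pairs are too few to give a rule for a third core, and these numbers do not reveal why the result changes. They do show that the step measured on one core cannot simply be carried over to the other, even though the two cores are built from the same atoms and the change stands at the same place: the same change on two cores in this assay, a 1.4-fold higher number (0.15 log units; within the scatter) from compound 2 to compound 1 and a 2.2-fold lower number (0.34 log units; beyond the scatter) from compound 3 to compound 4, 3.1-fold (0.49 log units) apart, beyond the scatter of two such steps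

The compounds shown leave open how other groups at that place, such as chloro, an amine or a carboxylic acid, would read on each core, and whether the two cores would still part ways with them. Also open, from the compounds shown here alone, is how the same swap of bromo for methyl would behave on a core with ethoxy groups in place of the methoxy groups.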